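This account rests on a few compounds, and the source may have more. Where it says the series, first, only, none or still open, it means among the compounds named here.

Measured compounds in a functional assay on L1210 cells (Mus musculus) for antiproliferative activity, read by MTT assay, with a stated time of 72 h; on this read-out higher numbers stand for weaker inhibition and lower numbers for stronger inhibition:
- compound 1 `COc1cc(C2=NN(C(C)=O)C(c3ccc([N+](=O)[O-])cc3)O2)cc(OC)c1OC` gives 4200 nM
- compound 2 `COc1ccc(C2OC(c3cc(OC)c(OC)c(OC)c3)=NN2C(C)=O)cc1OC(C)=O` gives 3900 nM
- compound 3 `COc1ccccc1C1OC(c2cc(OC)c(OC)c(OC)c2)=NN1C(C)=O` gives 48000 nM

Compound 3 stands at the highest number of the three, the weakest inhibitor in this assay; its nearest neighbour is compound 1 and the furthest is compound 2, both well beyond the scatter. Compounds 1 and 2 lie within the scatter of each other, so nothing is said of their order.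

The unmeasured compound 4 `COc1cc(C2=NN(C(C)=O)C(c3ccccc3)O2)cc(OC)c1OC` differs from compound 3 in one place: hydrogen in place of methoxy on an aromatic carbon

Among the compounds with values here, the only measured step in this assay concerns the same aryl group on the saturated ring carbon: an 11-fold higher number from compound 1 to compound 3 (1.06 log units; beyond the scatter). Within the data shown here, that step shows that the aryl substituent pattern on that carbon moves the number strongly, but no measured pair tests removal of a methoxy alone, so the direction for compound 4 is taken from the spread of the three values rather than from a matching step. Since the 2-methoxyphenyl compound 3 is the outlier on the high side, a phenyl group is expected to give a number lower than compound 3 but not necessarily as low as compound 1 or compound 2. The expected step is a 3.2-fold lower number from compound 3 to compound 4 (0.51 log units; beyond the scatter). Compound 4 is estimated at 15000 nM, with a range from 5000 nM to 45000 nM.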

Compound 4, half-maximal inhibitory concentration: 6400 nM
Compound 4: middle estimate off by 2.3-fold (0.37 log units), on the high side; the measured number falls inside the stated range.
By their numbers in this assay, from the lowest: compounds 2, 1 and 4 (each within the scatter of the next); then compound 3.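

In this assay, removing the methoxy from the aryl group on the saturated ring carbon gives a 7.5-fold lower number from compound 3 to compound 4 (0.88 log units; beyond the scatter), which ties the high number of compound 3 to that one methoxy, on an aromatic carbon ortho to a large group, rather than to the mere absence of the nitro group of compound 1. Going the other way on the same ring, a 1.5-fold higher number from compound 1 to compound 4 (0.18 log units; within the scatter) leaves phenyl and 4-nitrophenyl with no order between them, so among compounds 1, 3 and 4 only the 2-methoxyphenyl group stands apart at this position, and a nitro group is not needed to reach the lower numbers. Within the data shown here, nothing in hand bears on why the methoxy at this place raises the number so far.

Whether the rise is specific to methoxy remains open, since the compounds shown do not say what a hydroxyl group, a fluorine atom or an amine would give on that same aromatic carbon. Also open, going by these compounds, is whether a methoxy on another carbon of this ring would behave like compound 3 or like compound 4.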